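A few compounds are considered here, and "the series" means these few. Any claim that something is new, unique, unknown or untested is made for them only; others in the source may bear on it.

Measured compounds:
compound 1, `O=C(Nc1ncc(F)s1)[C@H](CC1CCCC1)n1cc(S(=O)(=O)C2CC2)cn1`, 0.91
compound 2, `O=C(Nc1ncc(Cl)s1)[C@H](CC1CCCC1)n1cc(S(=O)(=O)C2CC2)cn1`, 0.91
compound 3, `O=C(Nc1ncc(F)s1)[C@H](CC1CCOCC1)n1cc(S(=O)(=O)C2CC2)cn1`, 0.31

In an ADME assay on microsomes from liver (Homo sapiens) (on this read-out higher numbers stand for higher hepatic extraction and lower numbers for lower hepatic extraction), compound 3 stands lowest of the three numbers. Its nearest neighbour is compound 1, and the step a number 0.60 lower from compound 1 to compound 3 (beyond the scatter) is beyond the scatter, so compound 3 sits well apart from both compound 1 and compound 2, which share one number between them.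

Compound 4 is `O=C(Nc1ncc(Cl)s1)[C@H](CC1CCOCC1)n1cc(S(=O)(=O)C2CC2)cn1`, not yet measured. It differs from compound 3 in one place: chloro in place of fluoro on an aromatic carbon.

Within the data shown here, the one measured step that bears on this change is no change at the digits printed from compound 1 to compound 2 (within the scatter), the same exchange made on the pair that otherwise shares everything with compound 3 except the saturated chain substituent; that step left the read-out where it was. Among the measured compounds shown here, no other pair informs the estimate.

For compound 4 the expected step in this assay is therefore a number 0.020 higher from compound 3 to compound 4 (within the scatter), none beyond the scatter, because no change at the digits printed from compound 1 to compound 2 (within the scatter) showed no movement. Compound 4 is expected at 0.33, with a range of 0.2 to 0.5.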

Compound 4, hepatic extraction ratio: 0.31
For compound 4 the middle estimate is 0.020 above the measured one; measured number inside the range.
By their numbers in this assay, from the lowest: compounds 3 and 4 (each within the scatter of the next); then compounds 1 and 2 (each within the scatter of the next).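

Chloro in place of fluoro on the aromatic carbon next to the ring sulfur now reads on a second core, with oxan-4-yl on the chain, and in this assay it gives no change at the digits printed from compound 3 to compound 4 (within the scatter). The two readings of this exchange agree: the same change on two cores in this assay, no change at the digits printed (within the scatter) from compound 1 to compound 2 and no change at the digits printed (within the scatter) from compound 3 to compound 4, 0 apart, within the scatter of two such steps. The exchange of cyclopentyl for oxan-4-yl, so far read only with the 5-fluoro-1,3-thiazol-2-yl group, also holds with the 5-chloro-1,3-thiazol-2-yl group, giving a number 0.60 lower from compound 2 to compound 4 (beyond the scatter), and across these four compounds, none going against it, the number follows the chain substituent and not the halogen: the same change on two cores in this assay, a number 0.60 lower (beyond the scatter) from compound 1 to compound 3 and a number 0.60 lower (beyond the scatter) from compound 2 to compound 4, 0 apart, within the scatter of two such steps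

As far as these compounds go, only two halogens have been compared at this position, so whether a methyl or a nitrile on that aromatic carbon would move the number in this assay stays open. Also open, from the compounds shown here alone, is how a piperidin-4-yl group or a longer chain would read in place of oxan-4-yl.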